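Swapping chloro for trifluoromethoxy in a small series

The source may report more compounds than this note shows. Statements on the series, on what has been measured and on what is new or still open speak of the compounds shown alone.

In a functional assay on NCI-H460 cells (Homo sapiens) for inhibition, read by MTT assay, with a stated time of 24 h, tested at 10 ug/mL (a lower number here means less inhibition of growth, a higher number more inhibition of growth at the concentration tested), compound 1 `O=C(CCCCC(S)CCS)Nc1ccccc1` gives 8.37% of inhibition. For the measured compounds named here, compound 3 `O=C(CCCCC(S)CCS)Nc1ccc(Cl)cc1` gives 22% and holds the highest number so far. Compound 2 `O=C(CCCCC(S)CCS)Nc1cccc(Cl)c1` also carries a chloro and is reported as "not active" (no number reported) without a number.

The change to compound 4 `O=C(CCCCC(S)CCS)Nc1ccc(OC(F)(F)F)cc1` puts trifluoromethoxy in place of chloro on an aromatic carbon, para to a large group, and trifluoromethoxy in place of chloro on an aromatic carbon sums it up in counts. Going by the values given here, only one measured step bears on this, and only indirectly: chloro in place of hydrogen on an aromatic carbon gave a number 13.6 percentage points higher from compound 1 to compound 3 (beyond the scatter) as a modest move beyond the scatter. Among the compounds with values here, no measured compound carries trifluoromethoxy, and compound 2 shows that a chloro alone does not secure a number.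

The new group takes the place where compound 3 reached 22% so only a small change in this assay is expected, with no step beyond the scatter. The estimated step is a number 2 percentage points higher from compound 3 to compound 4 (within the scatter) and stays within the scatter. Compound 4 is expected at 24% with an estimated range of 8% to 45% around it.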

Compound 4, percent growth inhibition at one concentration: 29.2%
Beside the measured number, compound 4's estimate is 5.2 percentage points below it, within the range that was stated.
By their numbers in this assay, from the lowest: compound 1; then compounds 3 and 4 (each within the scatter of the next).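

In this assay, trifluoromethoxy on an aromatic carbon, para to a large group, can take the place of chloro without a change that stands out: the swap gives a number 7.2 percentage points higher from compound 3 to compound 4 (within the scatter). Compared with hydrogen at this place, the new group gives a number 20.8 percentage points higher from compound 1 to compound 4 (beyond the scatter), so a second group besides chloro now lies clear of hydrogen at this place, although the step is modest. No measurement shown here offers an explanation for these numbers.

The compounds shown leave open whether an amine or a carboxylic acid at this same place would keep a number of this size, and whether trifluoromethoxy would give a number at the place where the chloro of compound 2 sits. They also leave open what a longer chain on the shared core would do.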